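This account rests on a few compounds, and the source may have more. Where it says the series, first, only, none or still open, it means among the compounds named here.

The measured compounds in a functional assay on OVCAR-4 cells (Homo sapiens) for cytotoxicity, read by sulforhodamine B assay, with a stated time of 48 h; a higher number here means a weaker inhibitor of growth, a lower number a stronger inhibitor of growth:
Compound 1 `ClCc1ccccc1Cn1cnc2c(Cl)ncnc21` gives 12300 nM.
Compound 2 `ClCc1ccccc1Cn1cnc2ncnc(Cl)c21` gives 20400 nM.
Compound 3 `ClCc1cccc(Cn2cnc3nc(Cl)nc(Cl)c32)c1` gives 2950 nM.

Compound 2 has the highest number of the three. Its nearest neighbour is compound 1, whose number is lower by an amount within the scatter, so the two cannot be told apart. Going by the values given here, compound 3 sits far lower, beyond the scatter, but it differs from compound 2 in more than one place, so no single step connects them. Compound 4 `ClCc1ccccc1Cn1cnc2nc(Cl)nc(Cl)c21` is not yet measured. It differs from compound 2 by chloro in place of hydrogen on an aromatic carbon. Among the compounds with values here, no measured pair shows this change on its own. Because compound 3, which carries two chloro groups on its core, gives 2950 nM, a drop of modest size is expected, though not certain. Compound 4 is expected to give 6500 nM in this assay, with a range from 2000 nM to 20000 nM. That would be an expected step of a 3.1-fold lower number from compound 2 to compound 4 (0.50 log units; beyond the scatter).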

Compound 4, concentration for total growth inhibition: 5120 nM
Beside the measured number, compound 4's estimate is 1.3-fold (0.10 log units) above it; the range from low to high includes it.
By their numbers in this assay, from the lowest: compounds 3 and 4 (each within the scatter of the next); then compounds 1 and 2 (each within the scatter of the next).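

In this assay, going by these compounds alone, placing chloro instead of hydrogen on the aromatic carbon between two ring nitrogen atoms gives a 4.0-fold lower number from compound 2 to compound 4 (0.60 log units; beyond the scatter) and is the first single change in this set that can be read on its own. This position therefore accepts a chloro group, and growth inhibition improves modestly with it. Nothing measured here accounts for the change.

On these data alone, whether another group would do the same at this position remains open, such as an amine, a methoxy group or a methyl group. Also open, as far as these compounds go, is whether the gain depends on the other chloro group on the core.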